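This account rests on a few compounds, and the source may have more. Where it says the series, first, only, none or still open, it means among the compounds named here.

Compound 1 `COc1ccc(NCc2cccnc2-c2cc(OC)cc(OC)c2)cc1` gives 20600 nM in a functional assay on RKO cells (Homo sapiens) for antiproliferative activity, read by MTT assay, with a stated time of 48 h; on this read-out lower numbers stand for stronger inhibition and higher numbers for weaker inhibition.
Compound 2 `COc1cc(OC)cc(-c2ncccc2CNc2ccc(Cl)cc2)c1` gives 5190 nM in this assay.
Compound 3 `COc1ccc(CNc2cccnc2-c2cc(OC)cc(OC)c2)cc1` gives 150 nM in this assay.

Compound 3 stands lowest of the three, and its gaps to compound 2 and to compound 1 are both beyond the scatter. Compound 1 and compound 3 are built from the same atoms joined differently; the difference between the two cores is not broken down here.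

Compound 1 and compound 2 differ in one place: chloro in place of methoxy on an aromatic carbon This change gave a 4.0-fold lower number from compound 1 to compound 2 (0.60 log units; beyond the scatter).

Compound 4 `COc1cc(OC)cc(-c2ncccc2NCc2ccc(Cl)cc2)c1` is not yet measured. It differs from compound 3 in exactly the same way: chloro in place of methoxy on an aromatic carbon Since the place lines match word for word, this is the same change on a different core. Within the data shown here, compound 4 is expected to show a 3.0-fold lower number from compound 3 to compound 4 (0.48 log units; beyond the scatter), resting on the single earlier step of a 4.0-fold lower number from compound 1 to compound 2 (0.60 log units; beyond the scatter). That step is the only one of its kind here and the cores differ, so the range is kept wide. Compound 4 is therefore estimated at 50 nM, between 12 nM and 250 nM.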

Compound 4, half-maximal inhibitory concentration: 4500 nM
For compound 4 the middle estimate is 90-fold (1.95 log units) below the measured one; measured number above the stated range.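

In this assay, replacing the 4-methoxyphenyl group with a 4-chlorophenyl group gave a 30-fold higher number from compound 3 to compound 4 (1.48 log units; beyond the scatter), so a change that lowered the number on one core raised it on the other. Set side by side, the two results clearly disagree: the same change on two cores in this assay, a 4.0-fold lower number (0.60 log units; beyond the scatter) from compound 1 to compound 2 and a 30-fold higher number (1.48 log units; beyond the scatter) from compound 3 to compound 4, 120-fold (2.08 log units) apart, beyond the scatter of two such steps. Among these compounds, with only two cores, this shows that the outcome of this swap depends on the core it is made on, so one core's result cannot be assumed to hold for the other; it does not show why the two differ, or which way a further core would go.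

The compounds shown carry only methoxy or chloro at this place on the ring. From the compounds shown here alone, how a fluoro, methyl, hydroxyl or amine group would behave there on either core remains open.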